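This account rests on a few compounds, and the source may have more. Where it says the series, first, only, none or still open, it means among the compounds named here.

Compound 1 `COc1cccc(-c2cc(-c3ccc(C4NC(=O)c5ccccc5N4)cc3)nc(N)n2)c1OC`: > 400000 nM
Compound 2 `CC1(c2ccc(NC(c3ccc(Br)cc3)c3nnnn3C(C)(C)C)cc2)NC(=O)c2ccccc2N1`: > 400000 nM
Compound 3 `CC1(c2ccc(NC(c3ccc(Br)cc3)c3nnnn3C3CCCCC3)cc2)NC(=O)c2ccccc2N1`: > 400000 nM

In an ADME assay on Vero cells (Chlorocebus sabaeus) for cytotoxicity, read by MTT assay, with a stated time of 72 h (a lower number here means that less compound is tolerated, a higher number that more compound is tolerated), compound 1 gives > 400000 nM, which is a limit of the assay and not a number. Compound 2 gives the same kind of limit, > 400000 nM. Compound 3 is a limit too, at > 400000 nM. The readings so far therefore all sit at one ceiling: the limit of > 400000 nM in this assay, at which 3 of the 3 values shown sit.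

Compound 4 `Nc1nc(-c2ccc(Cl)cc2)cc(-c2ccc(C3NC(=O)c4ccccc4N3)cc2)n1` keeps the core of compound 1 and changes one group, with 4-chlorophenyl in place of 2,3-dimethoxyphenyl on an aromatic carbon. For the measured compounds named here, the only measured step, a step that the two limits leave unreadable from compound 2 to compound 3, concerns a different group on a different core, and its two limits give it no size. Going by the values given here, no measured step therefore bears directly on this change, and the true value of compound 1 is unknown. No change beyond the usual scatter is expected in this assay, so the expected step is small: an at least 1.1-fold lower number from compound 1 to compound 4 (0.05 log units; that floor lies within the scatter). The estimate for compound 4 is 350000 nM, with an expected range of 120000 nM to 400000 nM.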

Compound 4, half-maximal cytotoxic concentration: 323000 nM
Compound 4: the middle estimate sits 1.1-fold (0.03 log units) above what was measured, and the stated range covers the measured number.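

In this assay, for the compounds shown here, compound 4 is the first compound here to give a real number and not a limit, so this position on the shared core now has a reading that can be placed on a scale. Putting 4-chlorophenyl in place of 2,3-dimethoxyphenyl gives an at least 1.2-fold lower number from compound 1 to compound 4 (0.09 log units; that floor lies within the scatter) and so shows no change that can be told apart from ordinary repeat variation. Going by these compounds, the true size of that step remains unknown and the step between the two tetrazole-bearing compounds cannot be read at all, because the other readings rest on a ceiling: the limit of > 400000 nM in this assay, at which 3 of the 4 values shown sit.

On these data alone, whether an amine, a carboxylic acid or a longer chain at this position would bring the number clearly down remains open. Also open, as far as these compounds go, is how much of the reading belongs to the chlorine and how much to the two methoxy groups that leave, which a plain phenyl here could help to separate.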